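Methoxy added to the phenyl arm of compound 1

The source may report more compounds than this note shows. Statements on the series, on what has been measured and on what is new or still open speak of the compounds shown alone.

For the measured compounds named here, compound 1 `COc1cc(/C=C/C(=O)/C=C/c2ccccc2)ccc1OCc1cn(CCCCCOc2cc(=O)oc3ccccc23)nn1` stands lowest among the three compounds measured so far: in a functional assay on THP-1 cells (Homo sapiens) for inhibition, read by sulforhodamine B assay, with a stated time of 48 h, tested at 50 uM (a lower number here means less inhibition of growth, a higher number more inhibition of growth at the concentration tested), compound 1 gives 26%. Compound 2 `COc1cc(/C=C/C(=O)/C=C/c2cccc3ccccc23)ccc1OCc1cn(CCCCOc2cc(=O)oc3ccccc23)nn1` gives 54% and compound 3 `COc1cc(/C=C/C(=O)/C=C/c2cccc3ccccc23)ccc1OCc1cn(CCOc2cc(=O)oc3ccccc23)nn1` gives 89%; both numbers lie beyond the scatter above that of compound 1, but each of these two compounds differs from compound 1 in more than one place, so no single step can be read from them. Going by the values given here, compound 4 `COc1cccc(/C=C/C(=O)/C=C/c2ccc(OCc3cn(CCCCCOc4cc(=O)oc5ccccc45)nn3)c(OC)c2)c1` differs from compound 1 in one place only: methoxy in place of hydrogen on an aromatic carbon The series holds no measured pair that isolates such a change, so nothing measured tells its size. Compound 4 is expected to show a step of a number 6 percentage points higher from compound 1 to compound 4 (within the scatter) that stays within the scatter. Compound 4 is therefore estimated at 32%, with a range from 15% to 55%.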

Compound 4, percent growth inhibition at one concentration: 37%
The estimate for compound 4 lay 5 percentage points below the measured number; the measured number falls inside the stated range.
By their numbers in this assay, from the lowest: compound 1; then compound 4; then compound 2; then compound 3.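

On the phenyl arm, the change from phenyl to 3-methoxyphenyl gives the series its first reading at a single place: in this assay it produces a number 11 percentage points higher from compound 1 to compound 4 (beyond the scatter), modest in size. This position therefore accepts methoxy with no loss of growth inhibition. Nothing measured on the compounds explains the step.

As far as these compounds go, it remains open whether an amine or a carboxylic acid at this position would move the number further, or whether methoxy at another carbon of this ring would do the same. Also open, from the compounds shown here alone, is whether the change carries over to the different arm and chain of compound 2 and compound 3.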